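Trading a naphthol for a guaiacol in a semicarbazone series

A few compounds are considered here, and "the series" means these few. Any claim that something is new, unique, unknown or untested is made for them only; others in the source may bear on it.

The series shares one core, carrying a dimethylaminoethyl-triazolyl-pyridine ether and a fluorophenyl semicarbazone arm, and varies only the aryl group on the imine carbon. Compound 1 `COc1ccc(/C=N/NC(=O)Nc2ccc(Oc3ccnc(-c4nncn4CCN(C)C)c3)c(F)c2)c(OC)c1OC` bears a trimethoxyphenyl group, compound 2 `CN(C)CCn1cnnc1-c1cc(Oc2ccc(NC(=O)N/N=C/c3ccccc3)cc2F)ccn1` a plain phenyl, and compound 3 `CN(C)CCn1cnnc1-c1cc(Oc2ccc(NC(=O)N/N=C/c3c(O)ccc4ccccc34)cc2F)ccn1` a 2-hydroxynaphthalen-1-yl group. In an ADME assay on WI-38 cells (Homo sapiens) for cytotoxicity, read by MTT assay, with a stated time of 72 h (on this read-out higher numbers stand for weaker inhibition and lower numbers for stronger inhibition), compound 3 gives 3250 nM. In this assay, among the compounds with values here, compound 1 gives "not determined" (no result reported) and compound 2 gives "not determined" (no result reported), so compound 3 stands alone as the only compound with a number, and no comparison between measured compounds can be drawn.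

Compound 4 `COc1cc(/C=N/NC(=O)Nc2ccc(Oc3ccnc(-c4nncn4CCN(C)C)c3)c(F)c2)ccc1O` differs from compound 3 by one change: 4-hydroxy-3-methoxyphenyl in place of 2-hydroxynaphthalen-1-yl on a carbon with a double bond to nitrogen. The group that leaves is a fused two-ring system; the group that enters is a single ring carrying a hydroxyl and a methoxy group. Within the data shown here, no measured step speaks to this kind of exchange, so the expectation rests on the single value of compound 3 and on the size of the change. The expected step in this assay from compound 3 to compound 4 is a 1.7-fold higher number from compound 3 to compound 4 (0.23 log units; within the scatter), that is, a move toward weaker inhibition of cell growth, though one that may not exceed the usual scatter. On that basis compound 4 is expected to give about 5500 nM in this assay, within a range from 2000 nM to 16000 nM.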

Compound 4, half-maximal inhibitory concentration: 5320 nM
Estimate against measurement, compound 4: 1.0-fold (0.01 log units) above, within the range that was stated.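

Within the data shown here, until now this position had no measured step, and the exchange of 2-hydroxynaphthalen-1-yl for 4-hydroxy-3-methoxyphenyl on the carbon with a double bond to nitrogen supplies the first: in this assay, it gives a 1.6-fold higher number from compound 3 to compound 4 (0.21 log units; within the scatter). The fused two-ring system can therefore be replaced by a single ring carrying a hydroxyl and a methoxy group without the read-out leaving the usual scatter, so this pair cannot be told apart in this assay, and the smaller group with one more oxygen is tolerated on this evidence alone. Nothing available bears on why the two values lie so close, and no cause can be assigned to this result.

Any steps to compound 1 and compound 2 cannot be read, so the pair offers no view of how a group with no hydroxyl, such as the plain phenyl or the trimethoxyphenyl, compares in this assay. As far as these compounds go, it also remains open whether a quite different substituent on this aryl group, such as a carboxylic acid or an amine in place of the hydroxyl, would move the number beyond the scatter.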